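Swapping One Halogenated Phenyl Ring for Another

This account rests on a few compounds, and the source may have more. Where it says the series, first, only, none or still open, it means among the compounds named here.

Of the compounds shown here, two built on a shared core have been measured in a functional assay on SK-MEL-2 cells (Homo sapiens) for inhibition, read by sulforhodamine B assay, with a stated time of 48 h, tested at 10 uM; a lower number here means less inhibition, a higher number more inhibition at the concentration tested (going by the name of the read-out). Compound 1 `O=Cc1ccc(-c2cn3ccnc3c(-c3ccc4ncn(C5CCCCC5)c4c3)n2)cc1` gives 27.8%. Compound 2 `Clc1ccc(-c2cn3ccnc3c(-c3ccc4ncn(C5CCCCC5)c4c3)n2)cc1` gives 10.9%, the lower of the two numbers. Going by the values given here, the single measured step, a number 16.9 percentage points lower from compound 1 to compound 2 (beyond the scatter), shows how replacing one group on the phenyl ring of compound 1 moved the read-out.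

Compound 3 `Fc1ccccc1-c1cn2ccnc2c(-c2ccc3ncn(C4CCCCC4)c3c2)n1` has not been measured yet. It differs from compound 2 in one place: 2-fluorophenyl in place of 4-chlorophenyl on an aromatic carbon.

Among the compounds with values here, no measured step exchanges one halogenated phenyl ring for another, so the step from compound 1 to compound 2 bears on this change only loosely: it shows that altering this part of the molecule can shift the number by a modest amount. Because compound 2 already sits at 10.9%, there is little room for a further fall, and nothing measured points to a rise. I therefore expect little movement beyond the scatter, the estimated step being a number 2.1 percentage points higher from compound 2 to compound 3 (within the scatter). For compound 3 my estimate is 13%, expected to fall between 0% and 30%.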

Compound 3, a percentage reported as inhibition, at one concentration (the size of the read-out at that concentration, not a potency): 10.5%
Estimate against measurement, compound 3: 2.5 percentage points above, within the range that was stated.
By their numbers in this assay, from the lowest: compounds 3 and 2 (each within the scatter of the next); then compound 1.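

In this assay, the exchange of 4-chlorophenyl for 2-fluorophenyl changes both the halogen and its place on the phenyl ring, yet a number 0.4 percentage points lower from compound 2 to compound 3 (within the scatter) shows no difference that can be told from the scatter. The other new step, a number 17.3 percentage points lower from compound 1 to compound 3 (beyond the scatter), has much the same size as a number 16.9 percentage points lower from compound 1 to compound 2 (beyond the scatter), so among these three compounds the two halogenated phenyl rings read alike while the 4-formylphenyl ring of compound 1 stands apart. No measured evidence is available to explain this pattern.

Since the halogen and its place on the ring changed together, these compounds cannot show whether either change alone would move the number, or whether the two happen to cancel; 4-fluorophenyl and 2-chlorophenyl rings would separate the two. Going by these compounds, it also remains open whether the higher number of compound 1 belongs to the formyl group in particular or would also appear with another group in its place, such as a carboxylic acid, an amine or a nitrile.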